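Swapping chloro for nitro on compound 2's aromatic ring

The source may report more compounds than this note shows. Statements on the series, on what has been measured and on what is new or still open speak of the compounds shown alone.

Compound 1 `Cc1ccc(C(=O)CCc2nnc(-c3ccccc3)o2)c(C)c1` and compound 2 `Cc1ccc(C(=O)CCc2nnc(-c3ccc(Cl)cc3)o2)c(C)c1` share one core. In a functional assay on the whole organism (strain Wistar) for inhibition, with Rattus norvegicus as the target, with stated times of 30 min and 3 h, at a dose of 20 mg/kg by the oral route (a lower number here means less inhibition, a higher number more inhibition at the dose given (going by the name of the read-out)), compound 1 gives 58%, and compound 2 gives 72.6%, the higher of the two numbers, the step being a number 14.6 percentage points higher from compound 1 to compound 2 (beyond the scatter). Compound 3 `Cc1ccc(C(=O)CCc2nnc(-c3ccc([N+](=O)[O-])cc3)o2)c(C)c1` differs from compound 2 by nitro in place of chloro on an aromatic carbon. For the measured compounds named here, the only measured step, adding chloro in place of hydrogen, raised inhibition modestly; nothing measured shows what nitro in place of chloro does, so the step is expected to stay within the scatter, a number 4.6 percentage points lower from compound 2 to compound 3 (within the scatter). Compound 3 is therefore estimated at 68%, between 50% and 85%.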

Compound 3, a percentage reported as inhibition, in the whole organism at one dose (the size of the read-out at that dose, not a potency): 69.1%
Estimate against measurement, compound 3: 1.1 percentage points below; measured number inside the range.
By their numbers in this assay, from the lowest: compound 1; then compounds 3 and 2 (each within the scatter of the next).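

In this assay, nitro in place of chloro gives a number 3.5 percentage points lower from compound 2 to compound 3 (within the scatter), so the two groups cannot be told apart at this place on the aromatic ring. Nitro in place of hydrogen gives a number 11.1 percentage points higher from compound 1 to compound 3 (beyond the scatter), which shows that the gain over hydrogen is not confined to chloro. No available evidence explains why these two different groups give such similar numbers. On these data alone, it remains open whether an amine or a carboxylic acid on this carbon would keep inhibition at this level. As far as these compounds go, whether a methoxy group would do so is equally open.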